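The source may hold more compounds than are shown below. What is called first, only, known or untested is meant among the compounds shown, and "the series" means these compounds.

Three compounds of a shared core, all carrying the same anilide tail, have been tested so far in an assay on cells for agonist activity at D(4) dopamine receptor (Homo sapiens), read by luminescence and beta-arrestin recruitment, with a stated time of 90 min; a lower number here means that less compound is needed, a higher number that more compound is needed for the effect. Among the compounds with values here, compound 1 `Cc1cccc(NC(=O)CN2CCN(c3cccc4ccccc34)CC2)c1` is the only one to give a number: in this assay compound 1 reaches 9210 nM, a weak effect. Compound 2 `Cc1cccc(NC(=O)CN2CCN(c3ccc(Cl)cn3)CC2)c1` is reported in this assay as "not active" (no number reported), with no concentration given. Compound 3 `Cc1ccc(C2CCN(CC(=O)Nc3cccc(C)c3)CC2)nc1` likewise stands in this assay at "not active" (no number reported), so no number marks where it lies; it is one of two compounds here without a measured value, and only compound 1 offers a point of comparison.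

Compound 4 `Cc1ccc(C2CCN(CC(=O)Nc3cccc(C)c3)CC2)cc1` differs from compound 3 in one place: 4-methylphenyl in place of 5-methylpyridin-2-yl on a saturated ring carbon. The rest of the molecule, including the saturated ring and the anilide, is unchanged. Within the data shown here, no measured pair in this set shows what such an exchange does, so no size or direction of step can be read off; with compound 3 giving no number, there is also nothing to step from. Among the measured compounds shown here, the only hint is that the one active compound, compound 1, is itself weak.

On that basis, compound 4 is expected to remain weak or inactive in this assay, and if a number is obtained it is estimated near 15000 nM, with a plausible range from 3000 nM to 60000 nM.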

Compound 4, half-maximal effective concentration: "not active" (no number reported)
For compound 4 the study gives words and no number; no gap can be computed for the estimate.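

Compound 3 and compound 4 are both reported as not active in this assay, so no step can be read from exchanging 5-methylpyridin-2-yl for 4-methylphenyl. Nothing shown here explains this result. The compounds shown leave open whether any other group on this saturated ring carbon would give a measurable effect.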